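Cytotoxicity notes: dimethoxy change on the phenyl of compound 1

The compounds below may be only part of what the source reports. "The series", "measured", "known", "first", "only" and "open" are said of these compounds alone.

In an ADME assay on THP-1 cells (Homo sapiens) for cytotoxicity, read by MTT assay, with a stated time of 72 h (on this read-out lower numbers stand for higher toxicity in this test and higher numbers for lower toxicity in this test), compound 1 `COc1cc(OC)cc(-c2cn(Cc3cc(-c4ccccc4)no3)nn2)c1` gives 143000 nM. Within the data shown here, this is the only number available for the series, so compound 1 cannot be ranked against any other compound. Two close relatives add no number. For compound 2 `Cc1ccc(-c2cn(Cc3cc(-c4ccccc4)no3)nn2)cc1` the entry reads "not determined" (no result reported), and for compound 3 `Nc1ccc(-c2cn(Cc3cc(-c4ccccc4)no3)nn2)cc1` it reads "not determined" (no result reported).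

The next compound to be tested is compound 4 `COc1cc(OC)cc(-c2cn(Cc3cc(-c4ccc(OC)c(OC)c4)no3)nn2)c1`, which keeps the core of compound 1. It carries 3,4-dimethoxyphenyl in place of phenyl on an aromatic carbon of a five-membered aromatic ring with 1 nitrogen and 1 oxygen, next to the ring nitrogen. The counted difference is 3,4-dimethoxyphenyl in place of phenyl on an aromatic carbon.

Among the measured compounds shown here, no pair of measured compounds shows what a change of any kind does in this assay, so the expectation rests on the single value of compound 1 and carries wide margins. A slight drift toward lower numbers is expected, though nothing beyond the usual scatter. The estimated change is a 1.4-fold lower number from compound 1 to compound 4 (0.16 log units; within the scatter). Compound 4 is expected at 100000 nM, with an estimated range of 40000 nM to 250000 nM.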

Compound 4, half-maximal cytotoxic concentration: > 500000 nM
Compound 4: only a limit was reported; the forecaster's own chance of this, stated with the estimate: 15%; at least 5.0-fold (0.69 log units) between middle value and limit.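

Among these compounds, this is the first step that can be read: on an aromatic carbon of the five-membered aromatic ring with 1 nitrogen and 1 oxygen, next to the ring nitrogen, 3,4-dimethoxyphenyl in place of phenyl gives an at least 3.4-fold higher number from compound 1 to compound 4 (0.54 log units; beyond the scatter). In this assay compound 4 gives > 500000 nM, which is a limit of the assay and not a number, so the step fixes a direction and a minimum size but no exact size. The reading of the step as a minimum rests on that limit alone: the limit of > 500000 nM in this assay, at which 1 of the 4 values shown sits.

The compounds shown leave open how the step divides between the two added methoxy groups, and whether a carboxylic acid, an amine or a longer alkyl chain on this phenyl would move the number in the same direction. Compound 2 and compound 3 carry no number, so the aryl group at the other end of the shared core remains unread in this series, and a second change at either place would be needed before any pattern could be stated.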